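Three Measured Limits and a 3-Methylphenyl Analogue

The source may hold more compounds than are shown below. What is called first, only, known or untested is meant among the compounds shown, and "the series" means these compounds.

Three compounds share one core and were tested in an ADME assay on THP-1 cells (Homo sapiens) for cytotoxicity, read by MTT assay; on this read-out higher numbers stand for lower toxicity in this test and lower numbers for higher toxicity in this test. Compound 1 `Cc1nc(-c2cccnc2)sc1-c1nnc(-c2ccccc2Cl)o1`, compound 2 `COc1ccccc1-c1nnc(-c2sc(-c3cccnc3)nc2C)o1` and compound 3 `Cc1nc(-c2cccnc2)sc1-c1nnc(-c2ccc(Cl)cc2)o1` carry different aryl groups on that core. In this assay compound 1 gives only a limit, > 100 ug/mL. In this assay compound 2 also gives a limit, > 100 ug/mL. In this assay compound 3 likewise gives a limit, > 100 ug/mL. Compound 3 therefore stands at the limit of > 100 ug/mL in this assay, at which 3 of the 3 values shown sit. The steps a step that the two limits leave unreadable from compound 1 to compound 2, a step that the two limits leave unreadable from compound 1 to compound 3 and a step that the two limits leave unreadable from compound 2 to compound 3 cannot be read. Compound 4 `Cc1cccc(-c2nnc(-c3sc(-c4cccnc4)nc3C)o2)c1` differs from compound 3 by 3-methylphenyl in place of 4-chlorophenyl on an aromatic carbon. Since every bearing step is unreadable, no change beyond the scatter is expected in this assay. Compound 4 is expected to give 150 ug/mL, within 60 ug/mL to 400 ug/mL. The expected step is a step that the limit leaves unreadable from compound 3 to compound 4.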

Compound 4, half-maximal cytotoxic concentration: > 100 ug/mL
Compound 4: only a limit was reported; the forecaster's own chance of this, stated with the estimate: 85%; the middle value is on the limit's open side.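

In this assay, among these compounds, compound 4 gives only a limit, so no step among compound 1, compound 2, compound 3 and compound 4 can be read: the limit of > 100 ug/mL in this assay, at which 4 of the 4 values shown sit. The compounds shown leave open what half-maximal cytotoxic concentration any of them actually has, and whether their aryl groups differ at all in this assay.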